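Replacing dimethylamino on a carbonyl carbon with pyridin-4-yl

The source may hold more compounds than are shown below. What is called first, only, known or untested is meant among the compounds shown, and "the series" means these compounds.

Compound 1 `CC(=O)n1nc(NC(=O)c2ccccc2)c2c1CN(C(=O)C1CCC(C)CC1)C2`: 12200 nM
Compound 2 `CC(=O)n1nc(NC(=O)c2ccccc2)c2c1CN(C(=O)N(C)C)C2`: 70300 nM

Both compounds were tested in a functional assay on HCT-116 cells (Homo sapiens) for cytotoxicity, read by sulforhodamine B assay, with a stated time of 48 h; a lower number here means a stronger inhibitor, a higher number a weaker inhibitor. Compound 2 has the higher number of the two, which makes it the weaker inhibitor here. The next compound, compound 3 `CC(=O)n1nc(NC(=O)c2ccccc2)c2c1CN(C(=O)c1ccncc1)C2`, carries pyridin-4-yl in place of dimethylamino on a carbonyl carbon.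

Among the measured compounds shown here, only one measured step bears on this change: a 5.8-fold higher number from compound 1 to compound 2 (0.76 log units; beyond the scatter). It is a modest step beyond the scatter, seen when dimethylamino took the place of 4-methylcyclohexyl on a carbonyl carbon. Compound 3 loses dimethylamino again, but its incoming ring is not the 4-methylcyclohexyl of compound 1, and one step is thin evidence. A partial return is expected, an estimated 2.3-fold lower number from compound 2 to compound 3 (0.37 log units; beyond the scatter). For compound 3 the expected value is 30000 nM, with an estimated range from 9000 nM to 90000 nM.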

Compound 3, half-maximal inhibitory concentration: 10000 nM
Beside the measured number, compound 3's estimate is 3.0-fold (0.48 log units) above it; measured number inside the range.
By their numbers in this assay, from the lowest: compounds 3 and 1 (each within the scatter of the next); then compound 2.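

In this assay, the swap gives a 7.0-fold lower number from compound 2 to compound 3 (0.85 log units; beyond the scatter), so at this place on the carbonyl carbon a group other than 4-methylcyclohexyl can also take the number back down from that of compound 2. Against compound 1, the same pyridin-4-yl gives a 1.2-fold lower number from compound 1 to compound 3 (0.09 log units; within the scatter), so these two ring groups cannot be told apart here, and dimethylamino, the only one of the three without a ring, is the one that stands apart. No measurement is available to explain this difference.

Three groups cannot show whether a ring as such matters, or whether the nitrogen of pyridin-4-yl plays any part, and a plain phenyl group would separate those two ideas. On these data alone, it also stays open whether a larger amine such as piperidine would behave like dimethylamino or like the two ring groups.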